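The source may hold more compounds than are shown below. What is called first, only, known or untested is meant among the compounds shown, and "the series" means these compounds.

Compound 1, `CCSc1nc(Nc2cccc(OC)c2)c2ccncc2n1`: 10700 nM
Compound 2, `CCCSc1nc(Nc2cccc(OC)c2)c2ccncc2n1`: 17300 nM
Compound 3, `COc1cccc(Nc2nc(SCC3CC3)nc3cnccc23)c1`: 24900 nM

All three were tested in a functional assay on HepG2 cells (Homo sapiens) for inhibition, read by MTT assay, with a stated time of 72 h (a lower number here means a stronger inhibitor, a higher number a weaker inhibitor), and share one core, differing only in the group on a saturated chain carbon bound to a sulfur. Compound 3 gives the highest number of the three: one of its steps is a 1.4-fold higher number from compound 2 to compound 3 (0.16 log units; within the scatter) and lies within the scatter, while the other is a 2.3-fold higher number from compound 1 to compound 3 (0.37 log units; beyond the scatter) and lies beyond it.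

Compound 4, `COc1cccc(Nc2nc(SCC3CCCCC3)nc3cnccc23)c1`, carries this series one stage further: cyclohexyl in place of cyclopropyl on a saturated chain carbon bound to a sulfur. For the measured compounds named here, three measured steps bear on such growth at this carbon: a 1.6-fold higher number from compound 1 to compound 2 (0.21 log units; within the scatter), a 2.3-fold higher number from compound 1 to compound 3 (0.37 log units; beyond the scatter) and a 1.4-fold higher number from compound 2 to compound 3 (0.16 log units; within the scatter). Each enlargement gave the same or a higher number, never a lower one. Cyclohexyl is a larger addition than any of these, and the expected step is a 1.8-fold higher number from compound 3 to compound 4 (0.26 log units; within the scatter), a higher number, probably beyond the scatter. Compound 4 is therefore estimated at 45000 nM, with a range from 20000 nM to 110000 nM.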

Compound 4, half-maximal inhibitory concentration: 32800 nM
Estimate against measurement, compound 4: 1.4-fold (0.14 log units) above; low and high end bracket the measured number.
By their numbers in this assay, from the lowest: compounds 1, 2, 3 and 4 (each within the scatter of the next, the first and the last beyond it).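

Cyclohexyl is the largest group at this saturated chain carbon bound to a sulfur, yet in this assay it cannot be told apart from cyclopropyl (a 1.3-fold higher number from compound 3 to compound 4 (0.12 log units; within the scatter)) or from ethyl (a 1.9-fold higher number from compound 2 to compound 4 (0.28 log units; within the scatter)). Only against methyl does the gap clear the scatter (a 3.1-fold higher number from compound 1 to compound 4 (0.49 log units; beyond the scatter)), and even this widest step in the series is modest. The position therefore accepts a much bigger ring with only a small overall shift towards higher numbers, and no data here explain that shift.

Every group shown at this carbon is built from carbon alone, so it remains open whether an amine or a carboxylic acid would behave differently. Also open, from the compounds shown here alone, is whether a flat phenyl ring in place of cyclohexyl would give a lower number.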